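Replacing a Hydroxypropylsulfanyl Group With 3-Chlorophenyl

This account rests on a few compounds, and the source may have more. Where it says the series, first, only, none or still open, it means among the compounds named here.

Measured compounds:
- compound 1, `CCCOc1cc(C(F)(F)F)ccc1CNC(=O)C(C)c1ccc(NS(C)(=O)=O)c(F)c1`, 2 nM
- compound 2, `CC(C(=O)NCc1ccc(C(F)(F)F)cc1OC1CCCCC1)c1ccc(NS(C)(=O)=O)c(F)c1`, 0.7 nM
- compound 3, `CC(C(=O)NCc1ccc(C(F)(F)F)cc1SCCCO)c1ccc(NS(C)(=O)=O)c(F)c1`, "not active" (no number reported)

The three measured compounds share one core and differ only in the group attached to the aromatic carbon that carries the side chain. In an assay on CHO cells for antagonist activity at transient receptor potential cation channel subfamily V member 1 (Homo sapiens), read by FLIPR (a higher number here means a weaker inhibitor, a lower number a stronger inhibitor), compound 1 gives 2 nM and compound 2 gives 0.7 nM, the step of a 2.9-fold lower number from compound 1 to compound 2 (0.46 log units; beyond the scatter). Compound 3 stands apart: in this assay compound 3 is reported as "not active" (no number reported), with no single number attached, so it sits outside the range of the other two.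

Compound 4, `CC(C(=O)NCc1ccc(C(F)(F)F)cc1-c1cccc(Cl)c1)c1ccc(NS(C)(=O)=O)c(F)c1`, is not yet measured. It differs from compound 3 by 3-chlorophenyl in place of (3-hydroxypropyl)sulfanyl on an aromatic carbon. For the measured compounds named here, no measured step covers this particular exchange; the only measured step, from compound 1 to compound 2, concerns a change on an oxygen and is modest. Compounds 1 and 2 show that a hydrocarbon group at this carbon goes with strong inhibition, while compound 3 shows that the (3-hydroxypropyl)sulfanyl group does not. Compound 4 is therefore expected to return to the potent range, with an estimate of 5 nM, between 1 nM and 60 nM.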

Compound 4, inhibition constant: 1 nM
Compound 4: the middle estimate sits 5.0-fold (0.70 log units) above what was measured; low and high end bracket the measured number.
By their numbers in this assay, from the lowest: compounds 2, 4 and 1 (each within the scatter of the next, the first and the last beyond it).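

In this assay the step of a 1.4-fold higher number from compound 2 to compound 4 (0.15 log units; within the scatter) and the step of a 2.0-fold lower number from compound 1 to compound 4 (0.30 log units; within the scatter) both stay within the usual scatter, so 3-chlorophenyl cannot be told apart from cyclohexyloxy or propoxy here. This aromatic carbon therefore accepts a ring joined directly, with no oxygen link and with no hydrogen-bond donors or acceptors in the group. Compound 3 has no number, so its step to compound 4 cannot be read, and no measurement shown explains why one compound is active and the other is not.

From the compounds shown here alone, it remains open whether the sulfur or the hydroxyl of compound 3 goes with the lost activity, which a propylsulfanyl or a 3-hydroxypropoxy group would help separate. An unsubstituted phenyl group would show whether the chlorine matters at all.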